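The source may hold more compounds than are shown below. What is called first, only, known or untested is meant among the compounds shown, and "the series" means these compounds.

Measured compounds in an assay on HEK293 cells for inhibition of nuclear factor NF-kappa-B complex (Homo sapiens), read by a luciferase reporter, with stated times of 1 h and 3 h; a lower number here means a stronger inhibitor, a higher number a weaker inhibitor:

Compound 1, `CC(C)(C)CNC(=O)C[C@H](NC(=O)C(=O)c1c[nH]c2ccccc12)C(=O)N[C@@H](CCc1ccccc1)C(=O)NCc1ccccc1`, gives 25 nM.
Compound 2, `Cc1cc(C(=O)N[C@@H](CC(=O)NCC(C)(C)C)C(=O)N[C@@H](CCc2ccccc2)C(=O)NCc2ccccc2)no1`, gives 9 nM.
Compound 3, `CC(C)(C)CNC(=O)C[C@H](NC(=O)C(=O)c1c[nH]c2ccccc12)C(=O)N[C@@H](CCc1ccccc1)C(=O)NCc1ccccc1Cl`, gives 17 nM.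

The unmeasured compound 4, `Cc1cc(C(=O)N[C@@H](CC(=O)NCC(C)(C)C)C(=O)N[C@@H](CCc2ccccc2)C(=O)NCc2ccccc2Cl)no1`, is the counterpart of compound 3 in the same way that compound 2 is the counterpart of compound 1. The change from compound 3 to compound 4 is 5-methyl-1,2-oxazol-3-yl in place of (1H-indol-3-yl)carbonyl on a carbonyl carbon. The change from compound 1 to compound 2 is 5-methyl-1,2-oxazol-3-yl in place of (1H-indol-3-yl)carbonyl on a carbonyl carbon. The two place lines read the same word for word, so this is the same change made on two cores. The cores differ by chloro in place of hydrogen on an aromatic carbon, which on its own brought a 1.5-fold lower number from compound 1 to compound 3 (0.17 log units; within the scatter).

Within the data shown here, the one measured instance of the oxazole-for-indole exchange is a 2.8-fold lower number from compound 1 to compound 2 (0.44 log units; beyond the scatter), a modest step beyond the usual scatter. Among the measured compounds shown here, with only one such pair, there is no way to tell whether the chloro on the benzyl ring alters how much this exchange is worth; the data for this are absent. The account therefore rests on the assumption that the step carries over roughly unchanged from the core of compound 1 to the core of compound 3.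

Compound 4 is expected to give 6 nM in this assay, with a plausible range from 2.5 nM to 15 nM. This estimate means a step of a 2.8-fold lower number from compound 3 to compound 4 (0.45 log units; beyond the scatter), expected because compound 1 and compound 2 showed a 2.8-fold lower number from compound 1 to compound 2 (0.44 log units; beyond the scatter) for the same exchange, and the value of compound 3, 17 nM, is the starting point.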

Compound 4, half-maximal inhibitory concentration: 9 nM
Beside the measured number, compound 4's estimate is 1.5-fold (0.18 log units) below it; the range from low to high includes it.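

In this assay, placing 5-methyl-1,2-oxazol-3-yl where (1H-indol-3-yl)carbonyl stood on the chloro-bearing core brings a 1.9-fold lower number from compound 3 to compound 4 (0.28 log units; within the scatter), and this step does not differ measurably from the one seen on the core of compound 1: the same change on two cores in this assay, a 2.8-fold lower number (0.44 log units; beyond the scatter) from compound 1 to compound 2 and a 1.9-fold lower number (0.28 log units; within the scatter) from compound 3 to compound 4, 1.5-fold (0.17 log units) apart, within the scatter of two such steps Read the other way round, chloro in place of hydrogen gives no change at the digits printed from compound 2 to compound 4 (within the scatter), and this too agrees with its earlier counterpart: the same change on two cores in this assay, a 1.5-fold lower number (0.17 log units; within the scatter) from compound 1 to compound 3 and no change at the digits printed (within the scatter) from compound 2 to compound 4, 1.5-fold (0.17 log units) apart, within the scatter of two such steps The four compounds are therefore consistent with the exchange carrying over between these two cores, but they do not show that its size is the same, since the step lies beyond the scatter on one core and within it on the other, and a single set of four compounds cannot settle a small dependence on the core or show that the exchange would carry over to any further core.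

The compounds shown leave open whether the same agreement would hold with a fluoro or methoxy group in place of the chloro. They also leave open how an amine or a carboxylic acid would behave in place of the 5-methyl-1,2-oxazol-3-yl on either core.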